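Extending the enamide chain of compound 3

The source may hold more compounds than are shown below. What is called first, only, known or untested is meant among the compounds shown, and "the series" means these compounds.

The shared core of compound 1 `CCC/C=C/C(=O)N(Cc1ccc(OC)c(O)c1)c1cc(OC)c(OC)c(OC)c1` carries an amide whose carbonyl substituent is varied across the set. In a functional assay on KYSE-450 cells (Homo sapiens) for inhibition, read by MTT assay, with a stated time of 48 h (a lower number here means a stronger inhibitor, a higher number a weaker inhibitor), compound 1 gives 57 nM. Compound 2 `C#CC(=O)N(Cc1ccc(OC)c(O)c1)c1cc(OC)c(OC)c(OC)c1` gives 570 nM, and compound 3 `C=CC(=O)N(Cc1ccc(OC)c(O)c1)c1cc(OC)c(OC)c(OC)c1` gives 160 nM. On these numbers compound 3 stands second of the three, between the other two: a 2.8-fold higher number from compound 1 to compound 3 (0.45 log units; beyond the scatter), while a 3.6-fold lower number from compound 2 to compound 3 (0.55 log units; beyond the scatter).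

Compound 4 `CC/C=C/C(=O)N(Cc1ccc(OC)c(O)c1)c1cc(OC)c(OC)c(OC)c1` differs from compound 3 in one place: but-1-en-1-yl in place of vinyl on a carbonyl carbon. The measured step that bears on this change is a 2.8-fold higher number from compound 1 to compound 3 (0.45 log units; beyond the scatter), which describes the move from the longest chain to the shortest. But-1-en-1-yl lies between vinyl and pent-1-en-1-yl in chain length, and no measured compound sits at that length. A step toward a lower number is therefore expected, a 1.9-fold lower number from compound 3 to compound 4 (0.27 log units; within the scatter), smaller in size than a 2.8-fold higher number from compound 1 to compound 3 (0.45 log units; beyond the scatter). Compound 4 is expected to give about 85 nM, within a range of 40 nM to 180 nM.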

Compound 4, half-maximal inhibitory concentration: 72 nM
The estimate for compound 4 lay 1.2-fold (0.07 log units) above the measured number; the range from low to high includes it.
By their numbers in this assay, from the lowest: compounds 1 and 4 (each within the scatter of the next); then compound 3; then compound 2.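

In this assay, but-1-en-1-yl on the carbonyl carbon gives a step beyond the scatter when it replaces vinyl (a 2.2-fold lower number from compound 3 to compound 4 (0.35 log units; beyond the scatter)), and a larger one when it replaces ethynyl (a 7.9-fold lower number from compound 2 to compound 4 (0.90 log units; beyond the scatter)). The further move in chain length, between but-1-en-1-yl and pent-1-en-1-yl, gives no step that can be told from the scatter (a 1.3-fold higher number from compound 1 to compound 4 (0.10 log units; within the scatter)), so among the three alkenyl chains shown, the gain over vinyl is already complete at but-1-en-1-yl. Nothing available here accounts for these steps.

Open, going by these compounds, is whether a longer chain such as hept-1-en-1-yl would keep the number at this level or lose it. Also open, on these data alone, is whether the chain double bond matters, which a saturated propyl or butyl group on the same carbonyl carbon would test.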